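Swapping the Amine Tail: From Compound 3 to Compound 4

The source may hold more compounds than are shown below. What is called first, only, known or untested is meant among the compounds shown, and "the series" means these compounds.

Three measured compounds share one core and differ only in the amine at the end of the chain. In a functional assay on HepG2 cells (Homo sapiens) for antiproliferative activity, read by MTT assay, with a stated time of 72 h (on this read-out lower numbers stand for stronger inhibition and higher numbers for weaker inhibition), compound 1 `COc1cc2c(Nc3ccc(C#N)cc3)ncnc2cc1OCCCN1CCCC1` gives 20900 nM, compound 2 `COc1cc2c(Nc3ccc(C#N)cc3)ncnc2cc1OCCCN1CCCCC1` gives 20700 nM, and compound 3 `CCOC(=O)C1CCN(CCCOc2cc3ncnc(Nc4ccc(C#N)cc4)c3cc2OC)CC1` gives 57700 nM, the highest of the three and so the weakest inhibitor here; the steps of a 2.8-fold higher number from compound 1 to compound 3 (0.44 log units; beyond the scatter) and a 2.8-fold higher number from compound 2 to compound 3 (0.45 log units; beyond the scatter) both lie beyond the scatter, while a 1.0-fold lower number from compound 1 to compound 2 (0.00 log units; within the scatter) does not. Compound 4 `COc1cc2c(Nc3ccc(C#N)cc3)ncnc2cc1OCCCN1CCN(c2ccncc2)CC1` carries the change (4-(pyridin-4-yl)piperazin-1-yl in place of 4-(ethoxycarbonyl)piperidin-1-yl on a saturated chain carbon, three bonds along the chain from an oxygen on an aromatic ring). Going by the values given here, no measured step covers a pyridin-4-yl on a piperazine, so guidance is thin; the two steps into compound 3 show only that a larger tail did not help there. Compound 4 is expected to give about 25000 nM, between 8000 nM and 80000 nM, a step of a 2.3-fold lower number from compound 3 to compound 4 (0.36 log units; beyond the scatter).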

Compound 4, half-maximal inhibitory concentration: 12600 nM
Compound 4: middle estimate off by 2.0-fold (0.30 log units), on the high side; measured number inside the range.
By their numbers in this assay, from the lowest: compounds 4, 2 and 1 (each within the scatter of the next); then compound 3.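

In this assay, a large tail at this position does not by itself weaken the result: a 4.6-fold lower number from compound 3 to compound 4 (0.66 log units; beyond the scatter), even though 4-(pyridin-4-yl)piperazin-1-yl is no smaller than the group it replaces. The smaller tails cannot be separated from this one, with a 1.6-fold lower number from compound 2 to compound 4 (0.22 log units; within the scatter) and a 1.7-fold lower number from compound 1 to compound 4 (0.22 log units; within the scatter), both within the scatter. No measurement here gives a reason for the gap between the two large tails.

Going by these compounds, it remains open whether the pyridine ring matters or the piperazine alone is enough, which a 4-phenylpiperazin-1-yl tail would help to separate. On these data alone, how a morpholin-4-yl tail or a longer chain would behave also remains open.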